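The source may report more compounds than this note shows. Statements on the series, on what has been measured and on what is new or still open speak of the compounds shown alone.

Measured so far:
compound 1 `COCc1ccc(-c2ccc3nnc(C(N)=O)c(N[C@@H](C)C4CCOCC4)c3c2)cn1`: 5.6 uL/min
compound 2 `C[C@H](Nc1c(C(N)=O)nnc2ccc(-c3ccc(OCCCN(C)C)nc3)cc12)C1CCOCC1`: 3.4 uL/min

In an ADME assay on cells (Hepatocyte, Rattus norvegicus) for metabolic stability, read by HPLC, with a stated time of 30 min, tested at 1 uM (a higher number here means faster removal of the compound, a lower number slower removal), the two compounds are separated only by a 1.6-fold lower number from compound 1 to compound 2 (0.22 log units; within the scatter), so compound 2 sits at a number that cannot be told apart from that of compound 1. Compound 3 `C[C@H](Nc1c(C(N)=O)nnc2ccc(-c3ccc(OCCCN4CCCC4)nc3)cc12)C1CCOCC1` differs from compound 2 by pyrrolidin-1-yl in place of dimethylamino on a saturated chain carbon, three bonds along the chain from an oxygen on an aromatic ring. For the measured compounds named here, no measured step alters the amine on this chain; the only step known, a 1.6-fold lower number from compound 1 to compound 2 (0.22 log units; within the scatter), exchanges the whole side chain and stays within the scatter. The step of a 1.2-fold higher number from compound 2 to compound 3 (0.07 log units; within the scatter) is therefore expected to be none beyond the scatter. Compound 3 is estimated at 4 uL/min, within 2 uL/min to 8 uL/min.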

Compound 3, intrinsic clearance in a liver preparation (reported as CLH), per the amount of preparation that the assay uses: 1.9 uL/min
Compound 3: middle estimate off by 2.1-fold (0.32 log units), on the high side; measured number below the stated range.
By their numbers in this assay, from the lowest: compounds 3, 2 and 1 (each within the scatter of the next, the first and the last beyond it).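

In this assay the amine on the chain is now read on its own: pyrrolidin-1-yl in place of dimethylamino gives a step that stays within the scatter (a 1.8-fold lower number from compound 2 to compound 3 (0.25 log units; within the scatter)). For the compounds shown here, replacing methoxymethyl with the whole 3-(pyrrolidin-1-yl)propoxy group gives the only step here beyond the scatter, and a modest one (a 2.9-fold lower number from compound 1 to compound 3 (0.47 log units; beyond the scatter)). Nothing available explains either step.

Open, as far as these compounds go, is how a piperidine or a morpholine on the same chain would read, and whether a shorter ethoxy chain carrying pyrrolidine would give a similar number.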